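From hydroxymethyl to 2-carboxyethenyl: notes on growth inhibition

A few compounds are considered here, and "the series" means these few. Any claim that something is new, unique, unknown or untested is made for them only; others in the source may bear on it.

Measured in a functional assay on WiDr cells (Homo sapiens) for antiproliferative activity, read by sulforhodamine B assay, with a stated time of 48 h; on this read-out higher numbers stand for weaker inhibition of growth and lower numbers for stronger inhibition of growth:
- Compound 1 `CC(C)(C)[Si](C)(C)OC[C@H]1OCCC[C@H]1O[Si](C)(C)C(C)(C)C`: > 100000 nM (a limit)
- Compound 2 `CC(C)(C)[Si](C)(C)O[C@@H]1CCCO[C@@H]1CO`: > 100000 nM (a limit)

Compound 2 has no numerical value, only a limit of > 100000 nM. Compound 1 also stands only at a limit, > 100000 nM. The evidence so far is the limit of > 100000 nM in this assay, at which 2 of the 2 values shown sit.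

Compound 3 `CC(C)(C)[Si](C)(C)O[C@@H]1CCCO[C@@H]1/C=C/C(=O)O` differs from compound 2 by 2-carboxyethenyl in place of hydroxymethyl on a saturated ring carbon. In short, it has 2-carboxyethenyl in place of hydroxymethyl on a saturated ring carbon.

Among the compounds with values here, the only measured step is a step that the two limits leave unreadable from compound 1 to compound 2. Within the data shown here, it gives no size to carry over to this change, and no measured compound yet carries 2-carboxyethenyl. No step beyond the scatter is therefore expected in this assay, and no direction can be argued from the data. The estimated step is an at least 1.2-fold lower number from compound 2 to compound 3 (0.09 log units; that floor lies within the scatter). For compound 3 the estimate is 80000 nM, with an expected range of 30000 nM to 100000 nM. A reading that again gives only a limit is the likeliest outcome.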

Compound 3, concentration for 50% growth inhibition: > 100000 nM
Compound 3: no number, only a limit; the forecaster's own chance of this, stated with the estimate: 75%; at least 1.2-fold (0.09 log units) between middle value and limit.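

In this assay compound 2 and compound 3 each stand only at a limit, and no step can be read between them. The compounds shown leave open whether any of them inhibits growth at a measurable level, and whether replacing hydroxymethyl with 2-carboxyethenyl changes the read-out at all, with the series resting so far on this: the limit of > 100000 nM in this assay, at which 3 of the 3 values shown sit.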